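The compounds below may be only part of what the source reports. "The series", "measured", "known", "first", "only" and "open" are said of these compounds alone.

Measured so far, in a functional assay on DU-145 cells (Homo sapiens) for inhibition, read by trypan blue exclusion, with a stated time of 96 h; a higher number here means a weaker inhibitor of growth, a lower number a stronger inhibitor of growth:

compound 1 `O=C(/C(=C\c1ccc(O)cc1)SCc1ccc(F)cc1)c1ccc(Br)cc1`: 10000 nM
compound 2 `O=C(/C(=C\c1ccc(Cl)cc1)SCc1ccc(F)cc1)c1ccc(Cl)cc1`: 10000 nM
compound 3 `O=C(/C(=C\c1ccc(O)cc1)SCc1ccc(F)cc1)c1ccc(Cl)cc1`: 25000 nM

Compound 3 gives the highest of the three numbers in this assay, that is, the weakest growth inhibition seen. The two steps that lead to it are both modest: a 2.5-fold higher number from compound 1 to compound 3 (0.40 log units; beyond the scatter) and a 2.5-fold higher number from compound 2 to compound 3 (0.40 log units; beyond the scatter). Both of these changes sit on the aromatic rings at the ketone side and at the alkene end of the core; neither touches the 4-fluorobenzyl group on sulfur.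

Compound 4 `O=C(/C(=C\c1ccc(O)cc1)SCc1ccc(Cl)c(Cl)c1)c1ccc(Cl)cc1` differs from compound 3 only there: 3,4-dichlorophenyl in place of 4-fluorophenyl on a saturated chain carbon bound to a sulfur. For the measured compounds named here, no measured pair in this set varies the benzyl group on sulfur, so there is no step to lean on, and the two measured steps say nothing about this position. The working expectation is therefore a step no larger than the scatter, a 1.3-fold lower number from compound 3 to compound 4 (0.10 log units; within the scatter), with the direction open.

In this assay compound 4 is estimated at 20000 nM, within a range of 7000 nM to 60000 nM.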

Compound 4, concentration for 50% growth inhibition: 1000 nM
The estimate for compound 4 lay 20-fold (1.30 log units) above the measured number; the measured number lies below the stated range.
By their numbers in this assay, from the lowest: compound 4; then compounds 1 and 2 (each within the scatter of the next); then compound 3.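

The benzyl group on sulfur is a sensitive position in this assay: 3,4-dichlorobenzyl in place of 4-fluorobenzyl gives a 25-fold lower number from compound 3 to compound 4 (1.40 log units; beyond the scatter). For the compounds shown here, this large step far exceeds the modest steps seen so far on the aromatic rings at the ketone side and at the alkene end of the core, so the earlier compounds gave no sign of how much this position could matter. Nothing at hand bears on the reason for the size of this step.

Going by these compounds alone, the single step replaces the fluorine and adds two chlorines at once, so it leaves open how much a benzyl group with only one chlorine would retain. Also open, as far as these compounds go, are how an unsubstituted benzyl group, a longer chain on sulfur or an amine on the benzyl ring would compare, and whether the step holds with other groups on the two remaining rings.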